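Methyl removal from the aromatic ring of compound 3

The source may hold more compounds than are shown below. What is called first, only, known or untested is meant among the compounds shown, and "the series" means these compounds.

Three compounds have numbers in a functional assay on HeLa cells (Homo sapiens) for cytotoxicity, read by MTT assay, with a stated time of 72 h, tested at 30 uM; a lower number here means less inhibition of growth, a higher number more inhibition of growth at the concentration tested. Compound 1 `N/C(=N\NC(=S)N1CCOCC1)c1ccccn1` gives 82.8%, compound 2 `Cc1cccc(/C(N)=N/NC(=S)N2CCSCC2)n1` gives 85.3%, and compound 3 `Cc1ccnc(/C(N)=N/NC(=S)N2CCSCC2)c1` gives 78.3%. Compound 3 carries the lowest of the three numbers, yet its gaps to compound 1 and to compound 2 both lie within the scatter, so no order among the three can be read. Compound 4 `N/C(=N\NC(=S)N1CCSCC1)c1ccccn1` differs from compound 3 by one change: hydrogen in place of methyl on an aromatic carbon. Within the data shown here, no measured pair shows this change directly. Compound 1, without a methyl on the ring, and compound 2, with one, sit at similar numbers in this assay. The step of a number 3.7 percentage points higher from compound 3 to compound 4 (within the scatter) is expected to stay within the scatter, with no direction claimed. Compound 4 is estimated at 82%, with a range from 72% to 90%.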

Compound 4, percent growth inhibition at one concentration: 80.6%
Beside the measured number, compound 4's estimate is 1.4 percentage points above it; low and high end bracket the measured number.
By their numbers in this assay, from the lowest: compounds 3, 4, 1 and 2 (each within the scatter of the next).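

Hydrogen in place of methyl opposite the ring nitrogen gives a number 2.3 percentage points higher from compound 3 to compound 4 (within the scatter) in this assay and the same exchange on the other methylated ring gives a number 4.7 percentage points lower from compound 2 to compound 4 (within the scatter) so this change now has direct pairs, and this position shows no sensitivity to it beyond the scatter. Thiomorpholin-4-yl in place of morpholin-4-yl gives a number 2.2 percentage points lower from compound 1 to compound 4 (within the scatter) and also stays within the scatter. No supporting measurement bears on these steps.

Still open, from the compounds shown here alone, is whether an amine, a carboxylic acid or a longer chain such as propyl on this ring carbon would leave the scatter.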